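Compound 2 to Compound 3: a Methyl on the Amide Nitrogen

The compounds below may be only part of what the source reports. "The series", "measured", "known", "first", "only" and "open" are said of these compounds alone.

Measured compounds:
Compound 1, `CN1C/C(=C\c2ccc(Cl)cc2)C(=O)[C@@]2(C1)[C@H](c1ccc(Cl)cc1)CN(C)[C@]21C(=O)Nc2ccccc21`: 61.5%
Compound 2, `CN1C[C@@H](c2ccc(Cl)cc2)[C@@]2(Cc3ccccc3C2=O)[C@@]12C(=O)Nc1ccccc12`: 63.4%

Two spiro compounds have been tested in a functional assay on RPMI18226 cells (Homo sapiens) for antiproliferative activity, read by sulforhodamine B assay, with a stated time of 48 h, tested at 10 uM; a lower number here means less inhibition, a higher number more inhibition at the concentration tested (going by the name of the read-out). Compound 1 `CN1C/C(=C\c2ccc(Cl)cc2)C(=O)[C@@]2(C1)[C@H](c1ccc(Cl)cc1)CN(C)[C@]21C(=O)Nc2ccccc21` gives 61.5%, and compound 2 `CN1C[C@@H](c2ccc(Cl)cc2)[C@@]2(Cc3ccccc3C2=O)[C@@]12C(=O)Nc1ccccc12` gives 63.4%. Compound 2 stands at the upper of the two numbers, yet compound 1 lies within the scatter of it, so the two read as alike and no ranking between them is claimed.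

Compound 3 `CN1C(=O)[C@@]2(c3ccccc31)N(C)C[C@@H](c1ccc(Cl)cc1)[C@@]21Cc2ccccc2C1=O` has not been measured. It differs from compound 2 by methyl in place of hydrogen on an amide-type nitrogen in a ring. Within the data shown here, no step between measured compounds speaks to such a change, so the data offer no direction for it. The expected step of a number 5.4 percentage points lower from compound 2 to compound 3 (within the scatter) is small and is thought likely to fall within the scatter. Compound 3 is therefore estimated to give 58%, in a range from 35% to 80%.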

Compound 3, a percentage reported as inhibition, at one concentration (the size of the read-out at that concentration, not a potency): 86.6%
Compound 3: middle estimate off by 28.6 percentage points, on the low side, and the stated range ends below it.
By their numbers in this assay, from the lowest: compounds 1 and 2 (each within the scatter of the next); then compound 3.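

In this assay, methyl in place of hydrogen on an amide-type nitrogen in a ring gives a number 23.2 percentage points higher from compound 2 to compound 3 (beyond the scatter), so this position responds to a change of a single heavy atom. Compound 1 and compound 2 both carry the amide hydrogen, so neither could show how the read-out responds to a substituent at this nitrogen. Nothing available explains this gain in inhibition.

The compounds shown leave open whether the gain is particular to methyl or extends to ethyl, a longer chain, benzyl, or a chain ending in an amine on the same nitrogen. They also leave open whether methyl would have a similar effect on the core of compound 1, and, with one tested concentration, how the step would translate into potency.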